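Amide on the aniline nitrogen of compound 1

A few compounds are considered here, and "the series" means these few. Any claim that something is new, unique, unknown or untested is made for them only; others in the source may bear on it.

Compound 1, `Nc1ccc(/C=C2\SC(=O)N(Cc3ccc(Cl)cc3)C2=O)cc1`: 37000 nM
Compound 2, `CN1C(=O)S/C(=C\c2ccc(N)cc2)C1=O`: 99000 nM
Compound 3, `Nc1cccc(/C=C2\SC(=O)N(Cc3ccc(Cl)cc3)C2=O)c1`: 218000 nM

In a functional assay on L1210 cells (Mus musculus) for cytotoxicity, read by cell counting, with a stated time of 2 days (on this read-out lower numbers stand for stronger inhibition and higher numbers for weaker inhibition), compound 1 gives the lowest of the three numbers. The nearest of the others is compound 2, reached by the step of a 2.7-fold higher number from compound 1 to compound 2 (0.43 log units; beyond the scatter); the furthest is compound 3, reached by the step of a 5.9-fold higher number from compound 1 to compound 3 (0.77 log units; beyond the scatter). Both steps lie beyond the scatter, so compound 1 stands as the strongest inhibitor of the three in this assay.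

Compound 4, `C=C(Br)C(=O)Nc1ccc(/C=C2\SC(=O)N(Cc3ccc(Cl)cc3)C2=O)cc1`, differs from compound 1 in one place: (1-bromoethenyl)carbonyl in place of hydrogen on a nitrogen on an aromatic ring.

Neither measured step bears on this position. Within the data shown here, the step from compound 1 to compound 2 alters the group on the saturated chain carbon bound to the ring nitrogen of the core, and the step from compound 1 to compound 3 moves the amino group on the aromatic ring; neither touches the aniline nitrogen itself, and no measured pair shows what an acyl group there does. The expectation for compound 4 therefore rests on the structural change alone and carries a wide range. Compound 4 is expected to give 8000 nM in this assay, within 1500 nM to 40000 nM, meaning an estimated step of a 4.6-fold lower number from compound 1 to compound 4 (0.67 log units; beyond the scatter) towards stronger inhibition.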

Compound 4, half-maximal inhibitory concentration: 3400 nM
The estimate for compound 4 lay 2.4-fold (0.37 log units) above the measured number; measured number inside the range.
By their numbers in this assay, from the lowest: compound 4; then compound 1; then compound 2; then compound 3.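

In this assay, putting (1-bromoethenyl)carbonyl in place of hydrogen on the nitrogen on the aromatic ring gives an 11-fold lower number from compound 1 to compound 4 (1.04 log units; beyond the scatter), so this nitrogen need not stay free and a substituent on it can lower the number substantially. The two earlier changes, a 2.7-fold higher number from compound 1 to compound 2 (0.43 log units; beyond the scatter) and a 5.9-fold higher number from compound 1 to compound 3 (0.77 log units; beyond the scatter), both raised the number, which makes this the only change shown that moves it towards stronger inhibition. No measurement given here accounts for this drop.

The compounds shown do not tell which part of the entering group the drop depends on, and an acetyl group on the same nitrogen, carrying neither the bromine nor the carbon-carbon double bond, would be the plainest comparison. They also leave open whether (1-bromoethenyl)carbonyl would lower the number to a similar extent on the nitrogen of compound 2 or compound 3, where the rest of the molecule differs from compound 1.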